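One added methoxy on a weak growth inhibitor

This account rests on a few compounds, and the source may have more. Where it says the series, first, only, none or still open, it means among the compounds named here.

Measured in a functional assay on MCF7 cells (Homo sapiens) for inhibition, read by MTT assay, with a stated time of 24 h; a lower number here means a stronger inhibitor of growth, a higher number a weaker inhibitor of growth:
Compound 1 `COc1ccc(C(=O)n2c(-c3cn(C)c4ccccc34)nc3ccccc32)cc1`: 16300 nM
Compound 2 `COc1ccc(C(=O)n2c(-c3cn(C)c4ccccc34)nc3ccccc32)cc1OC`: 10200 nM
Compound 3 `Cn1cc(-c2nc3ccccc3n2C(=O)c2cccc(Br)c2)c2ccccc21`: 63400 nM

Compound 2 stands at 10200 nM, within the scatter of compound 1, while the measurements show a 6.2-fold higher number from compound 2 to compound 3 (0.79 log units; beyond the scatter). Compound 4 `COc1ccc2c(c1)c(-c1nc3ccccc3n1C(=O)c1ccc(OC)c(OC)c1)cn2C` differs from compound 2 by methoxy in place of hydrogen on an aromatic carbon. The new methoxy sits on a six-membered aromatic ring of carbon only, part of a fused or bridged system of two rings.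

One measured step makes the same kind of exchange, though elsewhere in the molecule: compound 2 arises from compound 1 with a 1.6-fold lower number from compound 1 to compound 2 (0.20 log units; within the scatter). The steps to compound 3, such as a 3.9-fold higher number from compound 1 to compound 3 (0.59 log units; beyond the scatter), replace a whole group on the carbonyl carbon and say little here. No step beyond the scatter is therefore expected in this assay, although a slight lean towards a lower number is possible. The estimated step is a 1.3-fold lower number from compound 2 to compound 4 (0.11 log units; within the scatter). Compound 4 is expected at 8000 nM, with an estimated range of 3000 nM to 21000 nM.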

Compound 4, concentration for 50% growth inhibition: 6300 nM
Compound 4: the middle estimate sits 1.3-fold (0.10 log units) above what was measured; measured number inside the range.
By their numbers in this assay, from the lowest: compounds 4, 2 and 1 (each within the scatter of the next, the first and the last beyond it); then compound 3.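

In this assay, a methoxy in place of hydrogen on this six-membered aromatic ring of carbon only, meta to a fused ring and para to a fused ring, gives a 1.6-fold lower number from compound 2 to compound 4 (0.21 log units; within the scatter). The earlier compounds shown here showed this exchange only on the aryl group on the carbonyl carbon, with a 1.6-fold lower number from compound 1 to compound 2 (0.20 log units; within the scatter), so the new step shows that this second site also takes a methoxy with no change beyond the scatter. Nothing available accounts for the size of this step.

From the compounds shown here alone, it remains open whether another group at this position, such as an amine, a carboxylic acid or a longer alkoxy chain, would move the number beyond the scatter. Going by these compounds, the effect of a methoxy on the other carbons of this ring also remains open.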